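The source may hold more compounds than are shown below. What is called first, only, known or untested is meant among the compounds shown, and "the series" means these compounds.

Measured so far:
- compound 1, `Cc1c(Cl)cccc1CCCCOc1ccc(C#Cc2cccc3c(CCCC(=O)O)c(C)n(CC(=O)O)c23)cc1`, 0.88 nM
- compound 2, `Cc1c(CCCC(=O)O)c2cccc(/C=C/c3ccc(OCCCCc4c(F)c(F)cc(F)c4F)cc3)c2n1CC(=O)O`, 3.7 nM
- compound 3, `Cc1c(Cl)cccc1CCCCOc1ccc(C#Cc2cccc3c(CC(=O)O)c(C)n(CCCCC(=O)O)c23)cc1`, 248 nM

These three compounds were tested in a functional assay on HEK293 cells for antagonist activity at cysteinyl leukotriene receptor 2 (Homo sapiens), read by fluorescence and calcium flux, with stated times of 30 min and 1 h; a lower number here means a stronger inhibitor, a higher number a weaker inhibitor. Compound 2 gives 3.7 nM, the second highest of the three numbers. Compound 1, the nearest, gives 0.88 nM, a lower number and a gap beyond the usual scatter. Compound 3 gives 248 nM, far higher than compound 2, again well beyond the scatter. Compound 2 is thus a strong inhibitor, though not as strong as compound 1 on these numbers.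

Compound 4, `Cc1c(F)cccc1CCCCOc1ccc(/C=C/c2cccc3c(CCCC(=O)O)c(C)n(CC(=O)O)c23)cc1`, has not yet been measured. It differs from compound 2 in one place: 3-fluoro-2-methylphenyl in place of 2,3,5,6-tetrafluorophenyl on a saturated chain carbon, four bonds along the chain from an oxygen on an aromatic ring. The rest of the molecule, including the shared core and the chain linking the two aromatic parts, is unchanged.

Going by the values given here, no directly comparable step between measured compounds exists for this change. Compound 1 carries a related aryl group, 3-chloro-2-methylphenyl, and gives 0.88 nM, but it also differs from compound 2 in its linker, so that comparison cannot be read as a clean step. The expectation for compound 4 is a small improvement, a step down of a 1.9-fold lower number from compound 2 to compound 4 (0.27 log units; within the scatter) in this assay, close to the edge of the scatter. Compound 4 is estimated at 2 nM, with a plausible range from 0.6 nM to 6 nM.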

Compound 4, half-maximal inhibitory concentration: 7.2 nM
Estimate against measurement, compound 4: 3.6-fold (0.56 log units) below; measured number above the stated range.
By their numbers in this assay, from the lowest: compound 1; then compounds 2 and 4 (each within the scatter of the next); then compound 3.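

In this assay, putting 3-fluoro-2-methylphenyl in place of 2,3,5,6-tetrafluorophenyl gives a 1.9-fold higher number from compound 2 to compound 4 (0.29 log units; within the scatter), so compound 2 and compound 4 cannot be told apart in this assay. Going by these compounds alone, this is the first clean step at this place on the chain, and it shows that two quite differently substituted aromatic rings can sit there with potency that stays in the same range. Nothing available here offers an explanation for this result.

One step cannot show how far this tolerance reaches: a plain phenyl, or a phenyl ring carrying an amine or a carboxylic acid, might read quite differently at this place. A shorter chain leading to the ring also remains an open question.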